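A few compounds are considered here, and "the series" means these few. Any claim that something is new, unique, unknown or untested is made for them only; others in the source may bear on it.

Compound 1, `O=C(Nc1ccc(C(=O)N2CCCN(CCN3CCCC3)c3sccc32)cc1)c1ccccc1-c1ccccc1`, gives 200 nM in an assay on CHO cells for inhibition of Vasopressin V2 receptor (Homo sapiens), read by radioligand binding; a higher number here means a weaker inhibitor, a lower number a stronger inhibitor.
Compound 2, `O=C(Nc1ccc(C(=O)N2CCCCc3sccc32)cc1O)c1ccccc1-c1ccccc1`, gives a reading of < 10 nM in this assay, which is a limit and not a number.
Compound 3, `CN(C)C1CCN(C(=O)COc2cc(C(=O)N3CCCCc4sccc43)ccc2NC(=O)c2ccccc2-c2ccccc2)CC1`, gives 8 nM in this assay.

Among the two readable numbers compound 3 stands lowest; its nearest neighbour is compound 1, whose number is higher by a gap beyond the scatter. The change from compound 2 to compound 3, a step that the limit leaves unreadable from compound 2 to compound 3, cannot be read in size, since the value of compound 2 is only a limit (the limit of < 10 nM in this assay, at which 1 of the 3 values shown sits).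

Compound 4, `CN1CCCN(C(=O)CCCOc2cc(C(=O)N3CCCCc4sccc43)ccc2NC(=O)c2ccccc2-c2ccccc2)CC1`, differs from compound 3 in one place: 2-((4-methyl-1,4-diazepan-1-yl)carbonyl)ethyl in place of (4-(dimethylamino)piperidin-1-yl)carbonyl on a saturated chain carbon bound to an oxygen on an aromatic ring. For the measured compounds named here, no measured step runs through this position with a readable size; the only step that touches the chain on that oxygen is the unreadable one from compound 2 to compound 3. An amine and the carbonyl linkage are kept in both, so the account expects no step beyond the scatter, a 1.3-fold higher number from compound 3 to compound 4 (0.10 log units; within the scatter). For compound 4 the estimate in this assay is therefore 10 nM, with a range from 3 nM to 35 nM.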

Compound 4, half-maximal inhibitory concentration: 10 nM
Compound 4: middle estimate and measured number agree at the digits printed; low and high end bracket the measured number.
By their numbers in this assay, from the lowest: compounds 3 and 4 (each within the scatter of the next); then compound 1.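

In this assay, replacing (4-(dimethylamino)piperidin-1-yl)carbonyl with 2-((4-methyl-1,4-diazepan-1-yl)carbonyl)ethyl on a saturated chain carbon bound to an oxygen on an aromatic ring gives a 1.3-fold higher number from compound 3 to compound 4 (0.10 log units; within the scatter), the first readable size for a change at this position. The step exchanges a six-membered non-aromatic ring with 1 hetero atom for a seven-membered non-aromatic ring with 2 hetero atoms and alters the chain to the carbonyl as well, yet the two numbers stay within the scatter of each other. The earlier step on this oxygen could show nothing of the kind, since compound 2 stands at a limit and not at a number: the limit of < 10 nM in this assay, at which 1 of the 4 values shown sits.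

The ring and the chain change together in this one step, so a 4-methyl-1,4-diazepan-1-yl carbonyl group on the chain of compound 3 would be needed to tell them apart. As far as these compounds go, whether a chain ending in a carboxylic acid, or a plain methyl group on this oxygen, would fit with compound 3 and compound 4 also stays open.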